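Title: From Two Carbamoyls to Chloro and Carbamoyl

The compounds below may be only part of what the source reports. "The series", "measured", "known", "first", "only" and "open" are said of these compounds alone.

The measured compounds and their values in the assay:

Compound 1 `Cn1c(-c2ccc(-c3cncnc3)cc2)nnc1C1(c2ccc(Cl)cc2)CCC1`: 46%
Compound 2 `Cn1c(-c2ccc(C(N)=O)cc2C(N)=O)nnc1C1(c2ccc(Cl)cc2)CCC1`: -11%
Compound 3 `Cn1c(-c2ccc(-c3cnccn3)cc2F)nnc1C1(c2ccc(Cl)cc2)CCC1`: 91%

In a functional assay on the whole organism (strain ICR) for inhibition, with Mus musculus as the target, read by scintillation counting, with a stated time of 4 h, at a dose of 10 mg/kg by the oral route (on this read-out higher numbers stand for more inhibition at the one dose given (going by the name of the read-out) and lower numbers for less inhibition), compound 2 gives -11%, the lowest of the three numbers. Compound 1 stands higher, beyond the scatter, and compound 3 stands higher still, also beyond the scatter. Compound 2 carries two carbamoyl groups on its six-membered aromatic ring of carbon only, while compound 1 and compound 3 carry aromatic groups at the same part of the shared core.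

Compound 4 `Cn1c(-c2ccc(C(N)=O)cc2Cl)nnc1C1(c2ccc(Cl)cc2)CCC1` differs from compound 2 in one place: chloro in place of carbamoyl on an aromatic carbon The carbamoyl leaves and a chloro group enters, ortho to a large group and meta to a carbamoyl group. One carbamoyl remains.

For the measured compounds named here, no step between measured compounds matches this change, so the size of the step in this assay cannot be read from the data. Given that compound 2 gives -11% and that compound 3, which has a small group ortho to the large aromatic group, gives 91%, a rise for compound 4 is expected, but a modest one, since the remaining carbamoyl is a feature no measured compound above compound 2 shares. The expected step from compound 2 to compound 4 is a number 31 percentage points higher from compound 2 to compound 4 (beyond the scatter). Compound 4 is estimated at 20%, with a range from -15% to 55%.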

Compound 4, a percentage reported as inhibition, in the whole organism at one dose (the size of the read-out at that dose, not a potency): 57%
Estimate against measurement, compound 4: 37 percentage points below, and the stated range ends below it.
By their numbers in this assay, from the lowest: compound 2; then compound 1; then compound 4; then compound 3.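

this assay records a number 68 percentage points higher from compound 2 to compound 4 (beyond the scatter) when chloro takes the place of carbamoyl on this aromatic carbon, ortho to a large group. The earlier compounds shown here offered no single-place comparison, and this one shows that the group at this carbon alone can move the read-out by a large amount. It also shows that a carbamoyl meta to this position does not by itself hold the number down, since compound 4 keeps that group and gives 57% in this assay, and no measurement at hand explains the rise.

On these data alone, whether a methyl, a methoxy or a nitrile on this carbon would match chloro, with the carbamoyl kept, stays open. So does what a carboxylic acid or an amine in place of the remaining carbamoyl would do alongside the chloro.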